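Adding a methoxy group across two related cores

The compounds below may be only part of what the source reports. "The series", "measured", "known", "first", "only" and "open" are said of these compounds alone.

This account concerns three measured compounds and one that is not yet measured, all assessed in a functional assay on OVCAR-4 cells (Homo sapiens) for cytotoxicity, read by sulforhodamine B assay, with a stated time of 48 h, tested at 100 uM; a lower number here means a stronger effect, a higher number a weaker effect of the compound at the concentration tested. Compound 1 `COc1ccc(-c2cc(/C=C/C(=O)c3ccc(N)cc3)[nH]n2)cc1` gives -68% in this assay. Compound 3 `COc1ccc(-c2cc(/C=C/C(=O)c3ccc(N)cc3)[nH]n2)cc1OC` is obtained from compound 1 by a single change, (methoxy in place of hydrogen on an aromatic carbon), and in this assay compound 3 gives -98%, so that the step is a number 30 percentage points lower from compound 1 to compound 3 (beyond the scatter). Compound 2 `COc1ccc(C(=O)/C=C/c2cc(-c3cc(OC)c(OC)c(OC)c3)n[nH]2)cc1OC` rests on a different core; how it differs from compound 1 is not broken down here. In this assay compound 2 gives -82%, which stands second highest of the three numbers, beyond the scatter from both compound 1 and compound 3.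

Compound 4 `COc1cc(C(=O)/C=C/c2cc(-c3cc(OC)c(OC)c(OC)c3)n[nH]2)cc(OC)c1OC` is not yet measured. It differs from compound 2 by methoxy in place of hydrogen on an aromatic carbon. Within the data shown here, this is the same kind of change as the one from compound 1 to compound 3, though not the same: in compound 4 the place is also meta to a methoxy group, which is not said of the place in compound 3. Among the measured compounds shown here, with only one such step known, the expectation for compound 4 rests on compound 1 and compound 3 and their step of a number 30 percentage points lower from compound 1 to compound 3 (beyond the scatter). Transferred to the core of compound 2, whose value is -82%, the same kind of change is expected to give a step of about a number 12 percentage points lower from compound 2 to compound 4 (beyond the scatter) in this assay, with compound 4 then estimated at -94%, between -105% and -82%.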

Compound 4, a percentage reported as activity, at one concentration (the size of the read-out at that concentration, not a potency): -98%
The estimate for compound 4 lay 4 percentage points above the measured number; low and high end bracket the measured number.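

On the second core, methoxy in place of hydrogen on an aromatic carbon gives a number 16 percentage points lower from compound 2 to compound 4 (beyond the scatter) in this assay. Set beside the earlier step, the change points the same way on both cores, and the sizes of the two steps cannot be told apart: the same change on two cores in this assay, a number 30 percentage points lower (beyond the scatter) from compound 1 to compound 3 and a number 16 percentage points lower (beyond the scatter) from compound 2 to compound 4, 14 percentage points apart, within the scatter of two such steps

Among these compounds, this shows that, in these two pairs, the direction of the step carries over from one core to the other, and that the data give no sign of a difference in its size between the cores; it does not show that the step has one fixed size, that it would carry over to any other core, or that the place of the added group is of no consequence, as the read-out comes from a single concentration and only two pairs are available.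

The compounds shown leave open whether a hydroxy group, an ethoxy group or a fluorine atom in the same place would move the read-out as methoxy does. Also open, from the compounds shown here alone, is how the amine of compound 3 would compare with a methoxy group in the same place on the same core.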